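The compounds below may be only part of what the source reports. "The series", "measured", "known", "first", "only" and "open" are said of these compounds alone.

Measured so far:
Compound 1 `O=C(/C=C/c1ccc(OCc2cn(Cc3ccccc3Br)nn2)cc1)c1ccc([N+](=O)[O-])cc1`: 32%
Compound 2 `O=C(/C=C/c1ccc(OCc2cn(Cc3ccc(Br)cc3)nn2)cc1)c1ccc([N+](=O)[O-])cc1`: 21%

In a functional assay on HepG2 cells (Homo sapiens) for inhibition, read by MTT assay, with a stated time of 48 h, tested at 10 uM (on this read-out lower numbers stand for less inhibition of growth and higher numbers for more inhibition of growth at the one concentration tested), compound 2 gives 21% and stands lowest of the two numbers; compound 1 gives 32%, a step beyond the scatter. Compound 3 `O=C(/C=C/c1ccc(OCc2cn(Cc3cccc(F)c3)nn2)cc1)c1ccc([N+](=O)[O-])cc1` carries 3-fluorophenyl in place of 4-bromophenyl on a saturated chain carbon bound to an aromatic nitrogen. For the measured compounds named here, the only measured step bearing on this ring, a number 11 percentage points lower from compound 1 to compound 2 (beyond the scatter), was modest. Going by the values given here, no step swaps bromine for fluorine, so the expected size of a number 4 percentage points higher from compound 2 to compound 3 (within the scatter) rests on that single step and is estimated as small, in either direction, likely within the scatter. Compound 3 is therefore expected at 25% with a range of 10% to 40%.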

Compound 3, percent growth inhibition at one concentration: 43%
Beside the measured number, compound 3's estimate is 18 percentage points below it; the whole stated range lies below it.
By their numbers in this assay, from the lowest: compound 2; then compound 1; then compound 3.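

In this assay, the group on a saturated chain carbon bound to an aromatic nitrogen spans more than the first pair showed, with a number 22 percentage points higher from compound 2 to compound 3 (beyond the scatter) and a number 11 percentage points higher from compound 1 to compound 3 (beyond the scatter) in this series. 3-fluorophenyl thus stands above both bromophenyl groups, each gap being beyond the scatter. Nothing available explains this rise.

Both steps change the halogen and its place together, leaving their separate shares open. From the compounds shown here alone, how an unsubstituted phenyl, or an amine or carboxylic acid on that ring, would read also remains open.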